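The source may hold more compounds than are shown below. What is called first, only, known or untested is meant among the compounds shown, and "the series" means these compounds.

Measured so far in a functional assay on CHO cells for antagonist activity at sphingosine 1-phosphate receptor 2 (Homo sapiens), read by GTPgammaS binding; a higher number here means a weaker inhibitor, a lower number a stronger inhibitor:
compound 1, `O=C(O)Cc1nn(Cc2cn3cc(OCC4CC4)c(Cl)cc3n2)c2ccccc2c1=O`, 30 nM
compound 2, `O=C(O)C1(c2nn(Cc3cn4cc(OCC5CC5)c(Cl)cc4n3)c3ccccc3c2=O)CC1`, 82 nM
compound 3, `CC(C)(C(=O)O)c1nn(Cc2cn3cc(OCC4CC4)c(Cl)cc3n2)c2ccccc2c1=O`, 105 nM

Compound 3 carries the highest of the three numbers in this assay; it is separated from compound 2 by a 1.3-fold higher number from compound 2 to compound 3 (0.11 log units; within the scatter), and from compound 1 by a 3.5-fold higher number from compound 1 to compound 3 (0.54 log units; beyond the scatter).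

The next compound, compound 4, `CCC(C(=O)O)c1nn(Cc2cn3cc(OCC4CC4)c(Cl)cc3n2)c2ccccc2c1=O`, keeps the same atoms as compound 3 but joins them differently: 1-carboxypropyl in place of 1-carboxy-1-methylethyl on an aromatic carbon.

Within the data shown here, no measured step moves from one branched acid to another of this kind. Among the measured compounds shown here, the steps that bear on it are those at the same position: a 2.7-fold higher number from compound 1 to compound 2 (0.44 log units; beyond the scatter) and a 3.5-fold higher number from compound 1 to compound 3 (0.54 log units; beyond the scatter), where the two branched acids gave modestly higher numbers than the carboxymethyl of compound 1, and a 1.3-fold higher number from compound 2 to compound 3 (0.11 log units; within the scatter), where the two branched acids sat close together. Compound 4 carries one alkyl branch and one hydrogen at that carbon, so in this assay its number is expected between the branched pair and compound 1, most likely not beyond the scatter from compound 3.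

The estimate for compound 4 in this assay is 70 nM, range 30 nM to 160 nM, meaning an expected step of a 1.5-fold lower number from compound 3 to compound 4 (0.18 log units; within the scatter).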

Compound 4, half-maximal inhibitory concentration: 43 nM
Compound 4: middle estimate off by 1.6-fold (0.21 log units), on the high side; measured number inside the range.
By their numbers in this assay, from the lowest: compounds 1, 4, 2 and 3 (each within the scatter of the next, the first and the last beyond it).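

In this assay, this position separates two acids built from the same atoms: moving from 1-carboxy-1-methylethyl to 1-carboxypropyl gives a modest step beyond the scatter (a 2.4-fold lower number from compound 3 to compound 4 (0.39 log units; beyond the scatter)), so the earlier closeness of the two branched acids does not extend to every branched acid. A single ethyl in place of hydrogen on the saturated chain carbon leaves the number within the scatter of the carboxymethyl of compound 1 (a 1.4-fold higher number from compound 1 to compound 4 (0.16 log units; within the scatter)). The 1-carboxypropyl group also stays within the scatter of 1-carboxycyclopropyl (a 1.9-fold lower number from compound 2 to compound 4 (0.28 log units; within the scatter)), so compound 4 cannot be ranked against either compound 1 or compound 2.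

From the compounds shown here alone, whether a longer chain such as propyl, or a hydroxyl on that carbon, would also stay within the scatter of compound 1 remains open. Nothing available here explains the step between the two isomeric acids.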